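A Bulkier Phenyl Group Tested Against a Kinase

This account rests on a few compounds, and the source may have more. Where it says the series, first, only, none or still open, it means among the compounds named here.

Compound 1, `CCCS(=O)(=O)Nc1ccc(F)c(C(=O)c2n[nH]c3ncc(-c4ccccc4)cc23)c1F`, gives 2.4% in an assay for binding affinity to dual specificity mitogen-activated protein kinase kinase 4 (Homo sapiens), read by KINOMEscan, tested at 100 nM; a higher number here means a weaker effect of the compound at the concentration tested, a lower number a stronger effect.
Compound 2, `CCCS(=O)(=O)Nc1ccc(F)c(C(=O)c2n[nH]c3ncc(-c4cccc(F)c4)cc23)c1F`, gives 8.2% in this assay.
Compound 3, `CCCS(=O)(=O)Nc1ccc(F)c(C(=O)c2n[nH]c3ncc(-c4cccc(O)c4)cc23)c1F`, gives 2.2% in this assay.

Compound 3 has the lowest of the three numbers, but the gaps to the others are small: a number 0.2 percentage points lower from compound 1 to compound 3 (within the scatter) and a number 6 percentage points lower from compound 2 to compound 3 (within the scatter), both within the scatter, as is a number 5.8 percentage points higher from compound 1 to compound 2 (within the scatter). The three compounds therefore cannot be told apart.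

Compound 4, `CCCS(=O)(=O)Nc1ccc(F)c(C(=O)c2n[nH]c3ncc(-c4ccc(C(C)(C)C)cc4)cc23)c1F`, carries 4-(tert-butyl)phenyl in place of 3-hydroxyphenyl on an aromatic carbon. All three measured steps change the group on that same phenyl ring, and none of them moved the number beyond the scatter, so a substituent change at this ring has so far been tolerated. Among the measured compounds shown here, the tert-butyl group is larger than anything tried, and no measured step covers such a group, which widens the uncertainty. A step of a number 7.8 percentage points higher from compound 3 to compound 4 (within the scatter) in this assay is expected, most likely within the scatter or slightly toward a weaker effect. Compound 4 is estimated at 10%, with a range from 1% to 45%.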

Compound 4, a percentage reported as activity, at one concentration (the size of the read-out at that concentration, not a potency): 46%
The estimate for compound 4 lay 36 percentage points below the measured number; the measured number lies above the stated range.
By their numbers in this assay, from the lowest: compounds 3, 1 and 2 (each within the scatter of the next); then compound 4.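

In this assay, the phenyl ring on the shared core turns out not to accept every group: the change to 4-(tert-butyl)phenyl gives a number 43.6 percentage points higher from compound 1 to compound 4 (beyond the scatter), and starting from the substituted rings it gives a number 37.8 percentage points higher from compound 2 to compound 4 (beyond the scatter) and a number 43.8 percentage points higher from compound 3 to compound 4 (beyond the scatter). Hydrogen, fluoro and hydroxy on this ring could not be told apart, so the tolerance they suggested does not extend to tert-butyl, and this is the first change here to weaken the effect beyond the scatter. Nothing available explains this loss.

As far as these compounds go, it remains open whether 4-methylphenyl or 4-isopropylphenyl would keep the stronger effect, which would show how much of the tert-butyl group can be accepted. From the compounds shown here alone, it is also open whether 3-(tert-butyl)phenyl would behave like 4-(tert-butyl)phenyl, and how an amine or a carboxylic acid on this ring would compare.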